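Where the Fluorine Sits on the Fluorophenyl Group

This account rests on a few compounds, and the source may have more. Where it says the series, first, only, none or still open, it means among the compounds named here.

Among the measured compounds shown here, in a functional assay on A549 cells (Homo sapiens) for cytotoxicity, read by MTT assay, with a stated time of 48 h (a lower number here means a stronger inhibitor, a higher number a weaker inhibitor), compound 2 `C=C1OC(=O)C=C1Cc1ccc(NC(=O)/C=C/c2ccccc2F)cc1` gives 7410 nM, the lower of the two numbers so far, while compound 1 `C=C1OC(=O)C=C1Cc1ccc(NC(=O)/C=C/c2cccc(F)c2)cc1` gives 35200 nM. Compound 3 `C=C1OC(=O)C=C1Cc1ccc(NC(=O)/C=C/c2ccc(F)cc2)cc1` carries 4-fluorophenyl in place of 2-fluorophenyl on a double-bonded chain carbon bound to a double-bonded chain carbon. For the measured compounds named here, one measured step bears on this change, the swap of 3-fluorophenyl for 2-fluorophenyl: a 4.8-fold lower number from compound 1 to compound 2 (0.68 log units; beyond the scatter). That modest step shows that the fluorine's position can matter, but it cannot settle the direction here. A modest rise is tentatively expected, as the estimated 2.0-fold higher number from compound 2 to compound 3 (0.31 log units; beyond the scatter). For compound 3, the expected value is 15000 nM, within an estimated range of 5500 nM to 40000 nM.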

Compound 3, half-maximal inhibitory concentration: 3460 nM
Compound 3: middle estimate off by 4.3-fold (0.64 log units), on the high side, and the stated range ends above it.
By their numbers in this assay, from the lowest: compound 3; then compound 2; then compound 1.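

In this assay, moving the fluorine to give 4-fluorophenyl in place of 2-fluorophenyl brings a 2.1-fold lower number from compound 2 to compound 3 (0.33 log units; beyond the scatter), which makes compound 3 the strongest of the three. The change from 3-fluorophenyl to 4-fluorophenyl is larger, with a 10-fold lower number from compound 1 to compound 3 (1.01 log units; beyond the scatter), so the same atoms joined differently give a clear order among these compounds. No evidence is available to explain that order. From the compounds shown here alone, it remains open whether 4-chlorophenyl, 4-methoxyphenyl or an unsubstituted phenyl at this place would match compound 3, and whether the order would hold in other cell lines.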